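The source may report more compounds than this note shows. Statements on the series, on what has been measured and on what is new or still open speak of the compounds shown alone.

Compound 1, `COc1cc(-c2nnc3n2NC(c2ccco2)C(C(=O)c2ccccc2)S3)cc(OC)c1OC`: in a functional assay on PC-3 cells (Homo sapiens) for cytotoxicity, read by MTT assay, with a stated time of 48 h (a lower number here means a stronger inhibitor, a higher number a weaker inhibitor), compound 1 gives 64300 nM.
Compound 2, `COc1cc(-c2nnc3n2NC(c2ccco2)C(C(=O)c2cccc4ccccc24)S3)cc(OC)c1OC`: in this assay compound 2 reaches only a limit of the assay, > 100000 nM.
Compound 3, `COc1cc(-c2nnc3n2NC(c2ccco2)C(C(=O)c2ccc(O)cc2)S3)cc(OC)c1OC`: in this assay compound 3 gives 38300 nM.

Compound 3 holds the lowest of the two numbers actually read, though its gap to compound 1, a 1.7-fold lower number from compound 1 to compound 3 (0.23 log units; within the scatter), is within the scatter, so the two cannot be ranked against each other. The third value, that of compound 2, is a limit (the limit of > 100000 nM in this assay, at which 1 of the 3 values shown sits).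

The next compound, compound 4, `COc1cc(-c2nnc3n2NC(c2ccco2)C(C(=O)c2ccco2)S3)cc(OC)c1OC`, differs from compound 3 in one place: furan-2-yl in place of 4-hydroxyphenyl on a carbonyl carbon. Two measured steps speak to this change. The hydroxy alone made little difference, as a 1.7-fold lower number from compound 1 to compound 3 (0.23 log units; within the scatter) shows. Exchanging the aryl group on the carbonyl carbon mattered more, since an at least 2.6-fold lower number from compound 2 to compound 3 (0.41 log units; beyond the scatter) is beyond the scatter and an at least 1.5-fold higher number from compound 1 to compound 2 (0.19 log units; that floor lies within the scatter) goes the same way, the bulkier group giving the higher number. Furan-2-yl is smaller than either, so no large loss is expected; the loss of the hydroxy points, if anywhere, to a slightly higher number. The step from compound 3 to compound 4 is therefore expected to be small, a 1.4-fold higher number from compound 3 to compound 4 (0.16 log units; within the scatter), in this assay. Compound 4 is estimated at 55000 nM, with a range from 20000 nM to 150000 nM.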

Compound 4, half-maximal inhibitory concentration: 58300 nM
Compound 4: the middle estimate sits 1.1-fold (0.03 log units) below what was measured, and the stated range covers the measured number.
By their numbers in this assay, from the lowest: compounds 3, 4 and 1 (each within the scatter of the next). At a limit, above all of these: compound 2.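

Replacing the six-membered carbon ring on the carbonyl carbon with furan-2-yl leaves the number in this assay within the scatter, whether the ring it replaces carries the hydroxy, with a 1.5-fold higher number from compound 3 to compound 4 (0.18 log units; within the scatter), or lacks it, with a 1.1-fold lower number from compound 1 to compound 4 (0.04 log units; within the scatter), so among compounds 1, 3 and 4 neither the ring change nor the loss of the hydrogen-bond donor gives a readable step at this position. Against naphthalen-1-yl the comparison yields only a floor, an at least 1.7-fold lower number from compound 2 to compound 4 (0.23 log units; that floor lies within the scatter), so compound 4 cannot be firmly separated from compound 2, unlike compound 3, whose floor against compound 2 lies beyond the scatter. Compound 2 stands at a limit and not at a number: the limit of > 100000 nM in this assay, at which 1 of the 4 values shown sits.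

From the compounds shown here alone, all four groups on this carbonyl carbon are aromatic rings, so it remains open how an open chain such as a propyl group or an amine would read at this position. Going by these compounds, it also remains open whether a substituent such as a carboxylic acid or a chlorine on the ring could move the number beyond the scatter from that of compound 3.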